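Swapping hydroxy for amino on a second chromene core

This account rests on a few compounds, and the source may have more. Where it says the series, first, only, none or still open, it means among the compounds named here.

Compound 1 `COc1ccc(C(=O)c2ccc(OC)c3c2OC(C)(C)C=C3)c(NC(=O)CO)c1` and compound 2 `COc1ccc(C(=O)c2ccc(OC)c3c2C=CC(C)(C)O3)c(NC(=O)CO)c1` share the same atoms joined differently; the difference between the two cores is not broken down here. In a functional assay on A2780 cells (Homo sapiens) for antiproliferative activity, read by MTT assay, with a stated time of 48 h (a higher number here means a weaker inhibitor, a lower number a stronger inhibitor), compound 1 gives 100 nM, while compound 2 gives 420 nM. Compound 3 `COc1ccc(C(=O)c2ccc(OC)c3c2OC(C)(C)C=C3)c(NC(=O)CN)c1` carries the change amino in place of hydroxy on a saturated chain carbon bound to a carbonyl carbon relative to compound 1. In this assay compound 3 gives 380 nM, a step of a 3.8-fold higher number from compound 1 to compound 3 (0.58 log units; beyond the scatter). The values of compound 2 and compound 3 lie within the scatter of each other. Compound 4 `COc1ccc(C(=O)c2ccc(OC)c3c2C=CC(C)(C)O3)c(NC(=O)CN)c1` carries the same change on the core of compound 2, namely (amino in place of hydroxy on a saturated chain carbon bound to a carbonyl carbon). Because this change gave a 3.8-fold higher number from compound 1 to compound 3 (0.58 log units; beyond the scatter), compound 4 is expected to show a step of about a 3.3-fold higher number from compound 2 to compound 4 (0.52 log units; beyond the scatter). Going by the values given here, compound 4 is therefore estimated at 1400 nM, with a range from 500 nM to 4000 nM, resting on the single measured step and on the unmeasured core transfer.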

Compound 4, half-maximal inhibitory concentration: 890 nM
For compound 4 the middle estimate is 1.6-fold (0.20 log units) above the measured one; low and high end bracket the measured number.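

In this assay the amino compound again gives the higher number on the second core, with a 2.1-fold higher number from compound 2 to compound 4 (0.33 log units; beyond the scatter) on the core of compound 2. So the change carries over between these two cores in direction, and the two steps cannot be told apart in size: the same change on two cores in this assay, a 3.8-fold higher number (0.58 log units; beyond the scatter) from compound 1 to compound 3 and a 2.1-fold higher number (0.33 log units; beyond the scatter) from compound 2 to compound 4, 1.8-fold (0.25 log units) apart, within the scatter of two such steps. Going by these compounds alone, this rests on only two pairs, so it does not show that the change would behave alike on any other core, nor why the number rises.

On these data alone, it remains open whether a dimethylamino group, a carboxylic acid or a longer chain at this place would follow the same course on both cores.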